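The source may hold more compounds than are shown below. What is called first, only, known or untested is meant among the compounds shown, and "the series" means these compounds.

Measured compounds: compound 1 `Cc1nc2c(OCc3ccccc3)cccn2c1N` gives 99% in a functional assay on the whole organism with Rattus norvegicus as the target, at a dose of 40 mg/kg by the intraperitoneal route; on this read-out lower numbers stand for less inhibition and higher numbers for more inhibition at the one dose given (going by the name of the read-out); compound 2 `Cc1nc2c(CCc3ccccc3)cccn2c1N` gives 47% in this assay; compound 3 `CC(=O)Nc1c(C)nc2c(OCc3ccccc3)cccn12` gives 93% in this assay.

Compound 4 `CC(=O)Nc1c(C)nc2c(CCc3ccccc3)cccn12` is not yet measured. Compound 2 and compound 1 carry different cores; the difference between the two cores is not broken down here, but compound 2 shows the lowest number of the three. From compound 1 to compound 3 the change is acetyl in place of hydrogen on a nitrogen on an aromatic ring, and the step it made in this assay is a number 6 percentage points lower from compound 1 to compound 3 (within the scatter). The same change, (acetyl in place of hydrogen on a nitrogen on an aromatic ring), leads from compound 2 to compound 4. Because the earlier step of a number 6 percentage points lower from compound 1 to compound 3 (within the scatter) stayed within the scatter, the step of a number 5 percentage points lower from compound 2 to compound 4 (within the scatter) is expected to be small as well. Compound 4 is therefore estimated at 42% in this assay, roughly between 22% and 62%.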

Compound 4, a percentage reported as inhibition, in the whole organism at one dose (the size of the read-out at that dose, not a potency): 40%
Compound 4: the middle estimate sits 2 percentage points above what was measured; the measured number falls inside the stated range.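

Amino to acetamido gave steps of like size on the two cores in this assay: the same change on two cores in this assay, a number 6 percentage points lower (within the scatter) from compound 1 to compound 3 and a number 7 percentage points lower (within the scatter) from compound 2 to compound 4, 1 percentage points apart, within the scatter of two such steps. The new step, a number 7 percentage points lower from compound 2 to compound 4 (within the scatter), therefore repeats the earlier one, and in these two pairs the change carried from the core of compound 1 to the core of compound 2 without a step beyond the scatter. Among these compounds, this rests on only two pairs in one read-out at a single dose, so it does not show that the change would stay this small on other cores or at other doses.

The compounds shown leave open how a longer acyl chain, such as propanoyl, or a methanesulfonyl group would fare in place of acetyl on that nitrogen. They also leave open whether the same change would hold on a core carrying a carboxylic acid.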